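Chromone ethers with amino-bearing side chains: antiproliferative screen

The source may report more compounds than this note shows. Statements on the series, on what has been measured and on what is new or still open speak of the compounds shown alone.

The series shares one core, carried in compound 1 `COc1cc(OC)c2c(=O)cc(-c3ccc(OCCBr)cc3)oc2c1`, compound 2 `COc1cc(OC)c2c(=O)cc(-c3ccc(OC4CCNCC4)cc3)oc2c1` and compound 3 `COc1cc(OC)c2c(=O)cc(-c3ccc(OCCCN)cc3)oc2c1`. In a functional assay (Homo sapiens) for antiproliferative activity, read by resazurin assay, with a stated time of 48 h, tested at 20 uM (a lower number here means a weaker effect, a higher number a stronger effect of the compound at the concentration tested), compound 1 gives 20%. In this assay compound 2 gives "not determined" (no result reported) and compound 3 gives "not determined" (no result reported), so compound 3 stands without a measured value, as does compound 2; only compound 1 offers a point of reference. Compound 4 `COc1cc(OC)c2c(=O)cc(-c3ccc(OCC(O)CN(C)C)cc3)oc2c1` has not yet been tested. It differs from compound 3 in one place: 2-(dimethylamino)-1-hydroxyethyl in place of 2-aminoethyl on a saturated chain carbon bound to an oxygen on an aromatic ring. No comparable measured step exists among these compounds, so the step in this assay is expected to stay small, without a clear direction beyond the usual scatter. Compound 4 is expected to give 20%, estimated between 0% and 45%.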

Compound 4, a percentage reported as inhibition, at one concentration (the size of the read-out at that concentration, not a potency): 71%
Compound 4: middle estimate off by 51 percentage points, on the low side, and the stated range ends below it.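

In this assay, replacing bromomethyl with 2-(dimethylamino)-1-hydroxyethyl on a saturated chain carbon bound to an oxygen on an aromatic ring gives a number 51 percentage points higher from compound 1 to compound 4 (beyond the scatter) on the shared core. This shows that the read-out at this position can respond strongly to the side chain, which compound 1 alone could not show. Nothing available explains this step. The steps from compound 2 and compound 3 cannot be read, so the hydroxyl and dimethylamino parts of the change remain inseparable. On these data alone, whether a morpholine or a diethylamino group on the same chain would give a similar read-out also remains open.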